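Swapping the aryl on the ring amine of compound 1

The compounds below may be only part of what the source reports. "The series", "measured", "known", "first", "only" and "open" are said of these compounds alone.

Measured so far:
- compound 1, `Cc1nc(-c2ccccc2)c(C(=O)N2CCN(c3cccc(C)c3C)CC2)o1`: 35 nM
- compound 2, `Cc1nc(-c2cccc(F)c2)c(C(=O)N2CCN(c3cc(Cl)cc(Cl)c3)CC2)o1`: 41.7 nM

In a functional assay on HL-60 cells (Homo sapiens) for inhibition, read by MTT assay, with a stated time of 72 h (on this read-out higher numbers stand for weaker inhibition and lower numbers for stronger inhibition), compound 1 gives 35 nM. Compound 2 gives 41.7 nM in this assay. Compound 1 has the lower of the two numbers, but the gap to compound 2 is within the scatter of repeated measurements, so the two cannot be told apart on this read-out. Compound 3, `Cc1nc(-c2ccccc2)c(C(=O)N2CCN(c3cccc(F)c3)CC2)o1`, has not yet been measured in this assay. It differs from compound 1 in one place: 3-fluorophenyl in place of 2,3-dimethylphenyl on an amine nitrogen in a ring. Among the compounds with values here, no measured pair shows what this exchange on the amine nitrogen does, so the expectation rests only on the closeness of compound 1 and compound 2, which carry different aryl groups at that position yet give similar numbers. The step from compound 1 to compound 3 is therefore expected to be small, a 1.7-fold higher number from compound 1 to compound 3 (0.23 log units; within the scatter), and may not exceed the scatter. Compound 3 is estimated to give 60 nM in this assay, within a range from 20 nM to 200 nM.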

Compound 3, half-maximal inhibitory concentration: 45 nM
Estimate against measurement, compound 3: 1.3-fold (0.12 log units) above, within the range that was stated.
By their numbers in this assay, from the lowest: compounds 1, 2 and 3 (each within the scatter of the next).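

In this assay, 3-fluorophenyl in place of 2,3-dimethylphenyl on the amine nitrogen in the ring gives a 1.3-fold higher number from compound 1 to compound 3 (0.11 log units; within the scatter), so compound 1 and compound 3 cannot be told apart on this read-out. Within the data shown here, this is the first direct pair at this position, and it shows that one exchange of the aryl group, with the rest of the molecule held constant, leaves the number within the usual scatter; a single pair like this supports no general rule about the position. No measurement here bears on why the two numbers stay so close, so the result remains a plain observation.

As far as these compounds go, both groups in this pair are substituted phenyl rings, so it remains open whether the same holds for a pyridine ring, a benzyl group or a phenyl ring carrying a carboxylic acid or an amine. The pair also cannot separate the contribution of each methyl group in 2,3-dimethylphenyl, which a 2-methylphenyl or a 3-methylphenyl group at the same nitrogen could address.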